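Compound 4: one flipped stereocentre at the assay limit

The source may hold more compounds than are shown below. What is called first, only, known or untested is meant among the compounds shown, and "the series" means these compounds.

Compound 1 `CC(C)C[C@@H](NC(=O)OC(C)(C)C)C(=O)N1CCC[C@H]1C(=O)N1[C@H](C(=O)OCc2ccccc2)[C@H]1C(=O)OCc1ccccc1` gives > 100000 nM as a limit
Compound 2 `CC(C)C[C@@H](NC(=O)OC(C)(C)C)C(=O)N1CCC[C@H](C(=O)N2[C@H](C(=O)O)[C@H]2C(=O)O)C1` reads "not determined" (no result reported) and so has no number
Compound 3 `CC(C)(C)OC(=O)NCC(=O)N1CCC[C@H]1C(=O)N1[C@H](C(=O)OCc2ccccc2)[C@H]1C(=O)OCc1ccccc1` gives > 100000 nM as a limit

In a functional assay on J774 cells (Mus musculus) for cytotoxicity, with a stated time of 48 h (a lower number here means a stronger inhibitor, a higher number a weaker inhibitor), compound 3 gives > 100000 nM as its result, which is a limit and not a number. Compound 3 thus stands at the limit of > 100000 nM in this assay, at which 2 of the 3 values shown sit, and has no exact value of its own.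

For compound 4 `CC(C)(C)OC(=O)NCC(=O)N1CCC[C@@H]1C(=O)N1[C@H](C(=O)OCc2ccccc2)[C@H]1C(=O)OCc1ccccc1` the change from compound 3 is this: the two compounds have the same atoms and bonds and differ only in configuration as drawn: 1 of 3 stereo elements differ; a stereocentre at a saturated ring carbon is drawn S in compound 3 and R in compound 4 and nothing leaves or enters.

Within the data shown here, only one measured step is available, a step that the two limits leave unreadable from compound 1 to compound 3 and it puts hydrogen in place of isobutyl on a saturated chain carbon. That step offers no size to carry over, and it is a different kind of change from the one at the saturated ring carbon. Compound 2 adds nothing either, with "not determined" (no result reported) as its entry.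

Among the measured compounds shown here, no measured pair here differs in configuration alone, so no step beyond the usual scatter is expected in this assay and no direction can be named. The expected size is a number no higher from compound 3 to compound 4 (the limit leaves the size open) and this remains an estimate. Compound 4 is estimated at 100000 nM with an expected range from 60000 nM to 200000 nM and will most likely be reported as a limit again.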

Compound 4, half-maximal inhibitory concentration: > 100000 nM
Compound 4 gave a limit, no number (the forecaster's own chance of this, stated with the estimate: 85%); the middle value lies on the limit itself.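

The step from compound 3 to compound 4 cannot be read in this assay, since both results are limits and not numbers: the limit of > 100000 nM in this assay, at which 3 of the 4 values shown sit.

With no exact number among them, the compounds shown leave open whether the configuration at the saturated ring carbon has any effect on the half-maximal inhibitory concentration.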